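The compounds below may be only part of what the source reports. "The series", "measured", "known", "first", "only" and "open" are said of these compounds alone.

Working notes on the series. Compound 1 `Cc1cc(C)c(CN2CCc3c(Cl)cc([C@H](CO)[C@@H]4CCCO4)c(Cl)c3C2=O)c(=O)[nH]1` gives 14.6 10^-6 cm/s in an ADME assay on MDCK cells (Canis lupus familiaris) for permeability, read by LC-MS, with a stated time of 90 min, tested at 2 uM (a lower number here means that the compound crosses the layer more slowly, a higher number that the compound crosses the layer faster), and this is its only numeric result, with one further entry carrying no single number. Compound 2 `Cc1cc(C)c(CN2CCc3c(Cl)cc(C(CO)C4CCOC4)c(Cl)c3C2=O)c(=O)[nH]1` is the only other measured comparator, at 2.5 10^-6 cm/s; 2.7 10^-6 cm/s (2 entries) in this assay. Compound 1 therefore has the higher value of the two. These two compounds do not make a measured step at a single point of change, so no direct measure of group replacement is available.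

Compound 3 `Cc1cc(C)c(CN2CCc3c(Cl)cc([C@@H](C)CO)c(Cl)c3C2=O)c(=O)[nH]1` is the next compound to read: methyl in place of oxolan-2-yl on a saturated chain carbon bound to an aromatic carbon and a saturated chain carbon. That is, methyl in place of oxolan-2-yl on a saturated chain carbon bound to an aromatic carbon and a saturated chain carbon.

Without a measured step to scale from, the expectation in this assay is for no change beyond the scatter, with a slight lean downward. The lean rests only on compound 2 at 2.5 10^-6 cm/s; 2.7 10^-6 cm/s (2 entries), which shows that a compound in this series can read well under compound 1. The expected step is a 1.6-fold lower number from compound 1 to compound 3 (0.21 log units; within the scatter). Compound 3 is estimated at 9 10^-6 cm/s, with an expected range of 3.5 10^-6 cm/s to 20 10^-6 cm/s.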

Compound 3, apparent permeability: 15 10^-6 cm/s
The estimate for compound 3 lay 1.7-fold (0.22 log units) below the measured number; measured number inside the range.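

In this assay, for the compounds shown here, the first readable step at this position is a 1.0-fold higher number from compound 1 to compound 3 (0.01 log units; within the scatter), for methyl in place of oxolan-2-yl on a saturated chain carbon bound to an aromatic carbon and a saturated chain carbon. The exchange removes a five-membered non-aromatic ring with 1 hetero atom, 1 hydrogen-bond acceptor and 1 defined stereocentre from that place, and the read-out still does not separate the two compounds. Repeat entries in this series can sit close together, which gives a sense of how tightly the assay reads here, as seen for compound 2: the several entries of compound 2 in this assay, 2.5 10^-6 cm/s; 2.7 10^-6 cm/s (2 entries)

The entries of compound 2 remain outside any readable step, so the compounds shown do not say what sets those readings apart from the others. On these data alone, it also remains open whether a larger change at this place, such as an amine, a carboxylic acid or a longer chain in place of methyl, would leave the read-out within the scatter as this exchange did.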